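This account rests on a few compounds, and the source may have more. Where it says the series, first, only, none or still open, it means among the compounds named here.

Compound 2, `COc1cc(OC)cc(C(=O)Nc2cccc(-c3oc4cc(-c5ccc(F)cc5)ccc4c(=O)c3O)c2)c1`, stands at the weaker end of the two numbers measured in a functional assay on HepG2 cells (Homo sapiens) for antiproliferative activity, read by CCK-8 assay, with a stated time of 72 h (on this read-out lower numbers stand for stronger inhibition and higher numbers for weaker inhibition), where compound 2 gives 23500 nM. Among the compounds with values here, its only neighbour, compound 1, `O=C(Nc1cccc(-c2oc3cc(-c4ccc(F)cc4)ccc3c(=O)c2O)c1)c1ccc(Cl)cc1`, gives 11000 nM in this assay, and the step of a 2.1-fold higher number from compound 1 to compound 2 (0.33 log units; beyond the scatter) is the single measured change at the aryl group on the carbonyl carbon. Compound 3, `O=C(Nc1cccc(-c2oc3cc(-c4ccc(F)cc4)ccc3c(=O)c2O)c1)c1ccc(-c2ccccc2)cc1`, has not yet been measured. It differs from compound 2 in one place: 4-phenylphenyl in place of 3,5-dimethoxyphenyl on a carbonyl carbon. Within the data shown here, no measured pair shows this particular exchange; the step from compound 1 to compound 2 is the only one that touches the same position, and it was modest, so the expectation is that an aryl exchange at this carbonyl carbon moves this assay by a similarly modest amount. Since compound 3 carries no oxygen on the entering group, as compound 1 does not, the number for compound 3 is expected to move back toward the number of compound 1, giving a 2.0-fold lower number from compound 2 to compound 3 (0.29 log units; within the scatter). The estimate for compound 3 in this assay is 12000 nM, with a range from 4000 nM to 36000 nM.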

Compound 3, half-maximal inhibitory concentration: 88500 nM
Estimate against measurement, compound 3: 7.4-fold (0.87 log units) below; measured number above the stated range.
By their numbers in this assay, from the lowest: compound 1; then compound 2; then compound 3.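

In this assay the aryl group on the carbonyl carbon proves able to shift the number further than the first pair alone showed: 4-phenylphenyl in place of 3,5-dimethoxyphenyl gives a 3.8-fold higher number from compound 2 to compound 3 (0.58 log units; beyond the scatter) and takes compound 3 to the top of the three numbers. The absence of oxygen on this aryl group does not place a compound near compound 1, since phenyl in place of chloro on an aromatic carbon gives an 8.0-fold higher number from compound 1 to compound 3 (0.91 log units; beyond the scatter) even though neither group carries oxygen, so among these three compounds oxygen on the group does not set the order. The data given here offer no measurement that could account for these steps.

The three compounds leave open whether the higher number of compound 3 follows from the second aromatic ring itself or would also appear with another group in its place, such as a cyclohexyl ring, a longer alkyl chain or a single methoxy group on the phenyl ring. They also leave open how an aryl group carrying an amine or a carboxylic acid would stand in this assay series, and whether any group at this carbonyl carbon would give a lower number than compound 1.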